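A piperazine replaces the amine chain of compound 2

The source may report more compounds than this note shows. Statements on the series, on what has been measured and on what is new or still open speak of the compounds shown alone.

Measured compounds:
Compound 1 `O=C(NCc1ccc(F)cc1)c1nc(Br)c2cccnc2c1NCc1ccc(F)cc1`: > 20000 nM, a limit
Compound 2 `CN(C)CCCNc1c(C(=O)NCc2ccc(F)cc2)nc(Br)c2cccnc12`: > 10000 nM, a limit

Both entries come from a functional assay on HCT-116 cells (Homo sapiens) for cytotoxicity, read by MTT assay, with a stated time of 72 h; a higher number here means a weaker inhibitor, a lower number a stronger inhibitor. Compound 2 stands at the limit of > 10000 nM in this assay, at which 1 of the 2 values shown sits, so it has a limit and no number. Compound 1 likewise has only a limit. For the measured compounds named here, the one measured step is a step that the two limits leave unreadable from compound 1 to compound 2, and it offers no size to carry forward.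

Compound 3 `O=C(NCc1ccc(F)cc1)c1nc(Br)c2cccnc2c1N1CCNCC1` is the next structure, with piperazin-1-yl in place of (3-(dimethylamino)propyl)amino on an aromatic carbon. With no readable step to go on, no change beyond the scatter is expected in this assay, and no direction can be argued. The expected step is a step that the limit leaves unreadable from compound 2 to compound 3. The estimate for compound 3 is 15000 nM, within an expected range of 5000 nM to 40000 nM.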

Compound 3, half-maximal inhibitory concentration: > 10000 nM
Compound 3 ended at the assay's limit (the forecaster's own chance of this, stated with the estimate: 65%); the middle value does not contradict the limit.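

For the compounds shown here, compound 3 stands at the limit > 10000 nM in this assay and compounds 1 and 2 also carry only limits, so no step among the three can be read. The compounds shown leave open whether (4-fluorobenzyl)amino, (3-(dimethylamino)propyl)amino or piperazin-1-yl differ at all in cytotoxicity.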